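Replacing 2-methylphenyl with 1,3-thiazol-2-yl on the chain

This account rests on a few compounds, and the source may have more. Where it says the series, first, only, none or still open, it means among the compounds named here.

In a functional assay on HUVEC cells (Homo sapiens) for cytotoxicity (a higher number here means that more compound is needed for the effect, a lower number that less compound is needed), compound 1 (`COC1=C(C)C(=O)/C(=C(O)/C=C/c2ccc(OC)cc2)C(=O)C1(C)C`) gives 2.5 ug/mL as its value, and compound 2 (`COC1=C(C)C(=O)/C(=C(O)/C=C/c2ccccc2C)C(=O)C1(C)C`) gives 2.3 ug/mL on the same measure. Among the measured compounds shown here, these two numbers lie within the scatter of each other, so compound 2 stands level with the only other compound that has a number. Compound 3 (`COC1=C(C)C(=O)/C(=C(O)/C=C/c2c(C)cc(C)cc2C)C(=O)C1(C)C`) shares the core, but compound 3 stands as "not determined" (no result reported) in this assay with no result reported.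

Compound 4 (`COC1=C(C)C(=O)/C(=C(O)/C=C/c2nccs2)C(=O)C1(C)C`) is still unmeasured. It carries 1,3-thiazol-2-yl in place of 2-methylphenyl on a double-bonded chain carbon bound to a double-bonded chain carbon, a change that counts as 1,3-thiazol-2-yl in place of 2-methylphenyl on a double-bonded chain carbon bound to a double-bonded chain carbon at that place. One five-membered aromatic ring with 2 hetero atoms thus replaces one six-membered aromatic ring of carbon only.

A single measured step bears on this. At the same place, 2-methylphenyl replacing 4-methoxyphenyl gave a 1.1-fold lower number from compound 1 to compound 2 (0.04 log units; within the scatter) and nothing larger. For the measured compounds named here, that step exchanged one six-membered carbon ring for another, and no measured compound carries a ring with hetero atoms there, so the guidance is thin. No step beyond the scatter, in either direction, is therefore expected in this assay, though the range is kept wide. The expected step is a 1.2-fold higher number from compound 2 to compound 4 (0.09 log units; within the scatter) as a best guess. For compound 4 the value is estimated at 2.8 ug/mL with a range from 1 ug/mL to 7.5 ug/mL as the expected span.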

Compound 4, concentration for half-maximal effect: 1.6 ug/mL
Estimate against measurement, compound 4: 1.8-fold (0.24 log units) above, and the stated range covers the measured number.
By their numbers in this assay, from the lowest: compounds 4, 2 and 1 (each within the scatter of the next).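

In this assay, the place on a double-bonded chain carbon bound to a double-bonded chain carbon now holds a ring with hetero atoms, which neither compound 1 nor compound 2 could show. Exchanging the six-membered aromatic ring of carbon only for 1,3-thiazol-2-yl gives a 1.4-fold lower number from compound 2 to compound 4 (0.16 log units; within the scatter), and setting the same group against 4-methoxyphenyl gives a 1.6-fold lower number from compound 1 to compound 4 (0.19 log units; within the scatter), so this place accepts a five-membered aromatic ring with 2 hetero atoms and the hydrogen-bond acceptors it brings without a step beyond the scatter. No measurement at hand accounts for this outcome.

As far as these compounds go, with no number for compound 3, it remains open in this assay whether more methyl groups on the phenyl ring would move the value at this place. Also open, from the compounds shown here alone, is whether anything here can produce a step beyond the scatter, for instance a carboxylic acid or an amine on the ring, a saturated ring such as piperidine, or a longer chain between the ring and the core.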